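The source may report more compounds than this note shows. Statements on the series, on what has been measured and on what is new or still open speak of the compounds shown alone.

Measured so far:

Compound 1, `CCC(=O)c1ccc(OCCCN2CCN(c3ncccn3)CC2)cc1`, in a functional assay on L5178Y cells (Mus musculus) for cytotoxicity, read by MTT assay; a lower number here means a stronger inhibitor, a higher number a weaker inhibitor: > 100 nM, which is a limit of the assay rather than a number.
Compound 2, `CCC(=O)c1ccc(OCCCN2CCN(c3cnccn3)CC2)cc1`, in this assay: 47.5 nM.
Compound 3, `CCC(C)(C)c1ccc(OCCCCN2CCN(c3cnccn3)CC2)cc1`, in this assay: 12.6 nM.

Compound 2 and compound 1 share one core and differ in one place: pyrimidin-2-yl in place of pyrazin-2-yl on an amine nitrogen in a ring. That change gives an at least 2.1-fold higher number from compound 2 to compound 1 (0.32 log units; beyond the scatter). Since compound 1 sits at the limit of > 100 nM in this assay, at which 1 of the 3 values shown sits, the true size of that step is not known, only its direction and its least size.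

Compound 3 has a different core; the difference between the two cores is not broken down here. Compound 4, `CCC(C)(C)c1ccc(OCCCCN2CCN(c3ncccn3)CC2)cc1`, is not yet measured in this assay. It differs from compound 3 by pyrimidin-2-yl in place of pyrazin-2-yl on an amine nitrogen in a ring, the same change as between compound 2 and compound 1, in the same place.

Compound 3 gives the lowest number of the measured set, and its nearest neighbour is compound 2. If the change behaves on the core of compound 3 as it did on the core of compound 2, compound 4 is expected to show a 3.2-fold higher number from compound 3 to compound 4 (0.50 log units; beyond the scatter) in this assay. This rests on a single measured step, an at least 2.1-fold higher number from compound 2 to compound 1 (0.32 log units; beyond the scatter), whose size is bounded only from one side. The estimate for compound 4 in this assay is 40 nM, expected between 18 nM and 120 nM.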

Compound 4, half-maximal inhibitory concentration: 46.4 nM
Compound 4: middle estimate off by 1.2-fold (0.06 log units), on the low side, within the range that was stated.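

In this assay, pyrimidin-2-yl in place of pyrazin-2-yl on the amine nitrogen in the ring gives a 3.7-fold higher number from compound 3 to compound 4 (0.57 log units; beyond the scatter), so the number rises on the core of compound 3 just as it did on the core of compound 2, and the change weakens the compound on both cores shown. Set side by side, the two steps compare as follows: the same change on two cores in this assay, an at least 2.1-fold higher number (0.32 log units; beyond the scatter) from compound 2 to compound 1 and a 3.7-fold higher number (0.57 log units; beyond the scatter) from compound 3 to compound 4; the limit leaves it open whether they differ. Compound 1 reads > 100 nM, which is a limit and not a number, so these two pairs show that the direction of the change carries from one core to the other, but they do not show that its size carries over as well, and two pairs do not make a rule for the whole series.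

The compounds shown leave open whether pyrazin-2-yl would also be favoured over other groups on that nitrogen, such as pyridin-2-yl or phenyl, and whether the same direction would hold on a core bearing an amine or a carboxylic acid. Within the data shown here, they also leave open how much each separate difference between the two cores contributes to the numbers, as no compound here changes just one of those features.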